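The compounds below may be only part of what the source reports. "The series", "measured", "known", "first", "only" and "open" are said of these compounds alone.

Compound 1 `O=S1(=O)Cc2nc(-c3cc(F)c(Cl)cc3F)nc(N3CCC(CO)CC3)c2C1` carries a hydroxymethyl group on a saturated ring carbon. In a functional assay on the whole organism (blood, strain ICR) with Mus musculus as the target, in the glucose tolerance test, with a stated time of 30 min (a higher number here means that more compound is needed for the effect, a lower number that less compound is needed), compound 1 gives 0.3 mg/kg. Compound 2 `O=C(O)C1CCN(c2nc(-c3cc(F)c(Cl)cc3F)nc3c2CS(=O)(=O)C3)CC1` has carboxy in that place. For compound 2 the result in this assay is only a limit, > 3 mg/kg, so no exact number is known for it. The change from hydroxymethyl to carboxy thus gave an at least 10-fold higher number from compound 1 to compound 2 (1.00 log units; beyond the scatter). On the numbers shown, compound 2 therefore stands at the weak end, sitting at the limit of > 3 mg/kg in this assay, at which 1 of the 2 values shown sits, while compound 1 stands at the lower number.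

Compound 3 `NC(=O)CCC1CCN(c2nc(-c3cc(F)c(Cl)cc3F)nc3c2CS(=O)(=O)C3)CC1` has not yet been measured in this assay. It differs from compound 2 in one place: 2-carbamoylethyl in place of carboxy on a saturated ring carbon. Among the compounds with values here, the only measured step that touches this position is the one from compound 1 to compound 2, an at least 10-fold higher number from compound 1 to compound 2 (1.00 log units; beyond the scatter), in which carboxy arrived and the number rose sharply. In compound 3 the carboxy leaves again, so a step back toward a lower number is expected, roughly an at least 3.0-fold lower number from compound 2 to compound 3 (0.47 log units; beyond the scatter), though how far remains uncertain since compound 2 is known only as a limit. Compound 3 is therefore estimated at about 1 mg/kg, with a likely range from 0.3 mg/kg to 3 mg/kg.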

Compound 3, minimum effective dose: 0.3 mg/kg
Estimate against measurement, compound 3: 3.3-fold (0.52 log units) above; low and high end bracket the measured number.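

The place three ring bonds from the ring nitrogen is not closed to a longer group: in this assay, replacing carboxy with 2-carbamoylethyl gave an at least 10-fold lower number from compound 2 to compound 3 (1.00 log units; beyond the scatter), so the high number of compound 2 does not carry over to every group placed there. The earlier step could not show this, as it compared only hydroxymethyl and carboxy, whereas hydroxymethyl and the longer 2-carbamoylethyl chain are not told apart in this assay, with no change at the digits printed from compound 1 to compound 3 (within the scatter). Among the three compounds, only compound 2 carries carboxy, and only compound 2 is known solely as a limit: the limit of > 3 mg/kg in this assay, at which 1 of the 3 values shown sits.

With so few groups at this place, the compounds shown leave open whether a carboxylic acid set further out on a longer chain, as in 2-carboxyethyl, would read like compound 2 or like compound 3. They also leave open how a plain ethyl chain with no carbonyl, or an amine such as aminomethyl, would compare with compound 1 and compound 3 in this assay.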